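The compounds below may be only part of what the source reports. "The series", "measured", "known", "first", "only" and "open" are said of these compounds alone.

Going by the values given here, compound 1, with the structure `Cc1cc(COc2ccccc2F)nc(-c2ccccn2)n1`, is the stronger-looking of the two compounds measured so far, but only on its face: in a functional assay on cells for antagonist activity at Free fatty acid receptor 1 (Homo sapiens), read by TR-FRET and inositol phosphate accumulation, with a stated time of 2 h (a lower number here means a stronger inhibitor, a higher number a weaker inhibitor), compound 1 gives 398 nM, and compound 2, with the structure `Cc1cc(COc2ccc(F)cc2)nc(-c2ccccn2)n1`, gives 631 nM in this assay. Among the compounds with values here, the one step between them, a 1.6-fold higher number from compound 1 to compound 2 (0.20 log units; within the scatter), lies inside the usual spread of repeated measurements, so compound 1 merely has the lower of two numbers that cannot be told apart.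

Compound 3, with the structure `Cc1cc(COc2cccc(F)c2F)nc(-c2ccccn2)n1`, keeps the whole of compound 1 and changes one thing: fluoro in place of hydrogen on an aromatic carbon. Within the data shown here, no measured step shows what such a change does here. Among the measured compounds shown here, the only step available moves a fluorine around the same ring and gives a difference within the scatter, so it bears on compound 3 only loosely. Compound 3 is therefore expected to sit close to compound 1, with a step of a 1.0-fold higher number from compound 1 to compound 3 (0.00 log units; within the scatter) and no change beyond the scatter. The estimate for compound 3 in this assay is 400 nM, expected to fall between 180 nM and 900 nM.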

Compound 3, half-maximal inhibitory concentration: 398 nM
Compound 3: the middle estimate sits 1.0-fold (0.00 log units) above what was measured; the range from low to high includes it.
By their numbers in this assay, from the lowest: compounds 1, 3 and 2 (each within the scatter of the next).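

Fluoro in place of hydrogen on an aromatic carbon, at the place ortho to a fluoro group and meta to a large group, gives no change at the digits printed from compound 1 to compound 3 (within the scatter) in this assay. The earlier step only moved a fluorine around the ring, whereas this one adds a fluoro group while the first stays in place, and it shows that this aromatic carbon can carry fluoro without the number leaving the scatter. That is a finding about one small group at one position, so it says that this particular swap makes no measurable difference here, not that the position is indifferent to every group, and no other measurement speaks to the reason for this result.

The compounds shown leave open what a group larger than fluoro, such as a methoxy group, an amine or a carboxylic acid, would do at this same aromatic carbon, where a clear step in either direction would show whether the position matters at all. As far as these compounds go, they also leave open how a ring with no fluoro group would compare with compound 1 and compound 3, so the contribution of fluoro itself remains unknown.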